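This account rests on a few compounds, and the source may have more. Where it says the series, first, only, none or still open, it means among the compounds named here.

In a functional assay on OVCAR-3 cells (Homo sapiens) for cytotoxicity, read by sulforhodamine B assay (on this read-out higher numbers stand for weaker inhibition of growth and lower numbers for stronger inhibition of growth), three compounds have been measured. Compound 1 (`CC1=CC[C@@H]([C@@](C)(O)CCCC(C)(C)NC(=S)N/N=C\c2ccc(C)cc2)CC1`) gives 11800 nM, compound 2 (`CC1=CC[C@@H]([C@@](C)(O)CCCC(C)(C)NC(=S)N/N=C\c2ccccc2[N+](=O)[O-])CC1`) gives 16200 nM, and compound 3 (`CC1=CC[C@@H]([C@@](C)(O)CCCC(C)(C)NC(=S)N/N=C\c2ccc([N+](=O)[O-])cc2)CC1`) gives 88600 nM. Compound 1 stands at the low end of these numbers, meaning stronger inhibition of growth, but it is not separated from its nearest neighbour: the measurements show a 1.4-fold higher number from compound 1 to compound 2 (0.14 log units; within the scatter). Its furthest neighbour is reached by a 7.5-fold higher number from compound 1 to compound 3 (0.88 log units; beyond the scatter).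

Compound 4 (`CC1=CC[C@@H]([C@@](C)(O)CCCC(C)(C)NC(=S)N/N=C(/C)c2ccccc2)CC1`) has not yet been measured. It has the same atoms as compound 1, joined differently: a group of 9 heavy atoms (8 carbon, 1 nitrogen; one six-membered aromatic ring of carbon only) in place of a group of 9 heavy atoms (8 carbon, 1 nitrogen; one six-membered aromatic ring of carbon only), on an amide-type nitrogen.

Among the compounds with values here, no measured step makes this exact change, so the evidence is indirect. All three measured steps alter the group carrying the aromatic ring. They are the step already shown as within the scatter, the modest 7.5-fold higher number from compound 1 to compound 3 (0.88 log units; beyond the scatter), and the modest 5.5-fold higher number from compound 2 to compound 3 (0.74 log units; beyond the scatter). Changes of this kind have therefore ranged from nothing detectable to modest. With compound 3 as the only large departure, at 88600 nM, no step beyond the scatter is expected here. The expected step in this assay is a 1.3-fold higher number from compound 1 to compound 4 (0.10 log units; within the scatter), slightly upward if it shows at all. For compound 4 the estimated value is 15000 nM, with an expected range from 6000 nM to 45000 nM.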

Compound 4, concentration for total growth inhibition: 59500 nM
Beside the measured number, compound 4's estimate is 4.0-fold (0.60 log units) below it; measured number above the stated range.
By their numbers in this assay, from the lowest: compounds 1 and 2 (each within the scatter of the next); then compounds 4 and 3 (each within the scatter of the next).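

In this assay, a 5.0-fold higher number from compound 1 to compound 4 (0.70 log units; beyond the scatter) comes from rearranging the group on the amide-type nitrogen, not from swapping in different atoms. The group that leaves and the group that enters have the same heavy-atom count, the same six-membered aromatic ring, the same double bond outside the ring and the same hydrogen-bond counts, so this position responds to how these atoms are joined, which a simple count of them would not reveal. Within the data shown here, until now, the only steps beyond the scatter led to compound 3, which carries a nitro group, whereas compound 4 shows that a step of this kind can occur with no nitro group present; no measurement here explains the change.

The compounds shown leave open whether the step follows from losing the methyl group from the aromatic ring or from gaining one on the carbon with a double bond to nitrogen, and a compound with an unsubstituted phenyl ring and a hydrogen on that carbon would help separate the two. On these data alone, it also remains open how an ethyl group on that same carbon would read in this assay.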